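Cyclohexylsulfanyl in place of dimethylpiperidinyl: expectation for compound 4

The compounds below may be only part of what the source reports. "The series", "measured", "known", "first", "only" and "open" are said of these compounds alone.

Three members of the series have numbers in an assay on CHO cells for antagonist activity at transient receptor potential cation channel subfamily V member 1 (Homo sapiens), read by FLIPR; on this read-out higher numbers stand for weaker inhibition and lower numbers for stronger inhibition. Compound 1 `CC(C(=O)NCc1ccc(C(F)(F)F)cc1N1CCCC1)c1ccc(NS(C)(=O)=O)c(F)c1` gives 2.3 nM, compound 2 `CC(C(=O)NCc1ccc(C(F)(F)F)cc1N1CCC(C)(C)CC1)c1ccc(NS(C)(=O)=O)c(F)c1` gives 1.3 nM, and compound 3 `CCCCCCOc1cc(C(C)(F)F)ccc1CNC(=O)C(C)c1ccc(NS(C)(=O)=O)c(F)c1` gives 0.8 nM. Among these three numbers compound 2 stands second highest: its nearest neighbour is compound 3, a lower number within the scatter, and its furthest is compound 1, a higher number, also within the scatter. Nothing separates the three beyond the scatter.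

Compound 4 `CC(C(=O)NCc1ccc(C(F)(F)F)cc1SC1CCCCC1)c1ccc(NS(C)(=O)=O)c(F)c1` has no number yet. It differs from compound 2 in one place: cyclohexylsulfanyl in place of 4,4-dimethylpiperidin-1-yl on an aromatic carbon. Both the leaving and the entering group are a six-membered non-aromatic ring carrying one hydrogen-bond acceptor and no donor, and the position, ortho to a large group and meta to the trifluoromethyl group, is unchanged. Going by the values given here, one measured step bears on this position: the exchange of one ring for another there, a 1.8-fold lower number from compound 1 to compound 2 (0.25 log units; within the scatter), which stayed within the scatter. No other change at this carbon has a number, and nothing is known of the cyclohexylsulfanyl group elsewhere in the series. The expectation for this assay is therefore a step not beyond the scatter, with its direction open. Compound 4 is estimated at 2 nM, with a range of 0.6 nM to 7 nM. The estimate means an expected step of a 1.5-fold higher number from compound 2 to compound 4 (0.19 log units; within the scatter).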

Compound 4, inhibition constant: 0.5 nM
Compound 4: the middle estimate sits 4.0-fold (0.60 log units) above what was measured; measured number outside the range, below it.
By their numbers in this assay, from the lowest: compounds 4, 3, 2 and 1 (each within the scatter of the next, the first and the last beyond it).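

In this assay, the aromatic carbon carrying these rings can shift the number beyond the scatter: cyclohexylsulfanyl gives a 2.6-fold lower number from compound 2 to compound 4 (0.41 log units; beyond the scatter) and a 4.6-fold lower number from compound 1 to compound 4 (0.66 log units; beyond the scatter), whereas the earlier ring exchange at the same carbon, a 1.8-fold lower number from compound 1 to compound 2 (0.25 log units; within the scatter), stayed within it. The same entering group gives a modest step beyond the scatter against both pyrrolidin-1-yl and 4,4-dimethylpiperidin-1-yl, and the step from the latter keeps a six-membered non-aromatic ring on both sides, so ring size is not what differs in that pair. No supporting measurement is available to explain this result, so these two steps describe the change without accounting for it.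

The compounds shown leave open whether the step follows the sulfur atom or the all-carbon ring, a question that cyclohexyloxy or cyclohexylmethyl at this carbon would address by keeping the carbon ring while replacing the sulfur. Also open, going by these compounds, is how far the ring itself can vary with the sulfur kept, as cyclopentylsulfanyl or phenylsulfanyl at the same carbon would show.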